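The compounds below may be only part of what the source reports. "The series", "measured", "known", "first", "only" and "open" are said of these compounds alone.

Working notes on the series. Compound 1 `CC1=C(C(=O)Nc2ccc(F)cc2)C(c2ccc([N+](=O)[O-])cc2)N=C(SCc2ccccc2)N1` is the reference point here. In a functional assay on the whole organism (artery, strain albino) with Rattus norvegicus as the target, with a stated time of 240 min, at a dose of 10 mg/kg by the oral route (on this read-out lower numbers stand for less inhibition and higher numbers for more inhibition at the one dose given (going by the name of the read-out)), compound 1 gives 32.3%. Compound 2 `CC1=C(C(=O)Nc2ccc(F)cc2)C(c2ccc([N+](=O)[O-])cc2)N=C(SCc2cccc(Cl)c2)N1` differs from compound 1 by chloro in place of hydrogen on an aromatic carbon, the chlorine sitting meta to a large group. In this assay compound 2 gives 15.9%, and the change amounts to a number 16.4 percentage points lower from compound 1 to compound 2 (beyond the scatter).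

Compound 3 `COc1ccc(C2N=C(SCc3ccccc3)NC(C)=C2C(=O)Nc2ccc(Br)cc2)cc1` is built on a different core; how the core of compound 3 differs from the core of compound 1 is not broken down here. In this assay compound 3 gives 13.3%. Against compound 2 this value lies within the scatter, so no order between compound 2 and compound 3 can be read; against compound 1 it lies beyond the scatter, lower.

Compound 4 `COc1ccc(C2N=C(SCc3ccccc3Cl)NC(C)=C2C(=O)Nc2ccc(Br)cc2)cc1` has not yet been measured in this assay. It differs from compound 3 by chloro in place of hydrogen on an aromatic carbon. The place line differs from that of the change from compound 1 to compound 2: there the chlorine is meta to a large group, here it is ortho to a large group, so this is the same kind of change, not the same change.

For compound 4 a downward step is expected, but a smaller one than the earlier one, because compound 3 already stands at 13.3% and little room remains below it; the expected step is a number 5.3 percentage points lower from compound 3 to compound 4 (within the scatter). The estimate for compound 4 in this assay is 8%, with a range from 0% to 22%.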

Compound 4, a percentage reported as inhibition, in the whole organism at one dose (the size of the read-out at that dose, not a potency): 15.4%
Estimate against measurement, compound 4: 7.4 percentage points below, within the range that was stated.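

In this assay, for the compounds shown here, the change from hydrogen to chloro on the benzyl ring does not carry over as one fixed step from one core to the other: the same change on two cores in this assay, a number 16.4 percentage points lower (beyond the scatter) from compound 1 to compound 2 and a number 2.1 percentage points higher (within the scatter) from compound 3 to compound 4, 18.5 percentage points apart, beyond the scatter of two such steps Read alone, the new step, a number 2.1 percentage points higher from compound 3 to compound 4 (within the scatter), sets no order within that pair, so on the core of compound 3 the 2-chlorobenzyl group gives no readable change from benzyl. Going by these compounds alone, this does not show that the core alone sets the size of the step, as the chlorine in compound 4 stands ortho to a large group and the chlorine in compound 2 stands at another place on the ring, so core and place change together, and each core contributes only one pair, at a single oral dose that gives no measure of potency.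

Still open, as far as these compounds go, is how the step reads with the chlorine at the same place on both cores, which would separate the role of the core from that of the place. Also open, from the compounds shown here alone, is how an amine or a carboxylic acid on the benzyl ring, or a longer chain in place of benzyl, would read in this assay on either core.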